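The compounds below may be only part of what the source reports. "The series", "measured", "known", "first", "only" and "open" are said of these compounds alone.

Going by the values given here, in an assay for inhibition of Tryptophan 2,3-dioxygenase (Homo sapiens), with stated times of 10 min and 60 min, tested at 100 uM (on this read-out higher numbers stand for a stronger effect at the one concentration tested and lower numbers for a weaker effect), compound 3 `O=[N+]([O-])c1ccccc1CNc1cccc2[nH]ncc12` gives 87%, the second highest of the three numbers measured so far. Compound 1 `O=[N+]([O-])c1ccccc1CNc1cc(C(F)(F)F)cc2[nH]ncc12` gives 95%, and compound 2 `N#Cc1cc(NCc2ccccc2[N+](=O)[O-])c2cn[nH]c2c1` gives 41%. The step of a number 8 percentage points lower from compound 1 to compound 3 (within the scatter) lies within the scatter, while the step of a number 46 percentage points higher from compound 2 to compound 3 (beyond the scatter) is large and well beyond it.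

Compound 4 `COC(=O)c1cc(NCc2ccccc2[N+](=O)[O-])c2cn[nH]c2c1` differs from compound 3 by methoxycarbonyl in place of hydrogen on an aromatic carbon. Among the compounds with values here, two measured steps bear on filling this position: the step of a number 8 percentage points lower from compound 1 to compound 3 (within the scatter) shows that a trifluoromethyl here changes little, whereas the step of a number 46 percentage points higher from compound 2 to compound 3 (beyond the scatter) shows that a cyano here costs a great deal. The two earlier outcomes thus span a wide range, and the new group is a third, untested kind of substituent at the same place. The estimated step of a number 27 percentage points lower from compound 3 to compound 4 (beyond the scatter) is therefore expected to be a drop beyond the scatter, but smaller than the loss seen with cyano. Compound 4 is estimated to give about 60%, with a likely range from 25% to 90%.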

Compound 4, a percentage reported as inhibition, at one concentration (the size of the read-out at that concentration, not a potency): 20%
Beside the measured number, compound 4's estimate is 40 percentage points above it; the measured number lies below the stated range.
By their numbers in this assay, from the lowest: compound 4; then compound 2; then compounds 3 and 1 (each within the scatter of the next).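

The step of a number 67 percentage points lower from compound 3 to compound 4 (beyond the scatter) in this assay shows that methoxycarbonyl can nearly abolish the effect seen with hydrogen at this position, and the step of a number 75 percentage points lower from compound 1 to compound 4 (beyond the scatter) shows how far it falls short of trifluoromethyl at the same place. The step of a number 21 percentage points lower from compound 2 to compound 4 (beyond the scatter) adds that methoxycarbonyl costs more than cyano, so two of the three groups tried here lower the number, while trifluoromethyl goes against any simple rule that filling this position is harmful. No measurement shown explains why these groups differ.

As far as these compounds go, whether a carboxylic acid or a primary amide at this position would behave like methoxycarbonyl or like trifluoromethyl remains open. So does whether a simple methyl or a chlorine atom here would keep the number close to that of compound 3 in this assay as the read-out.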